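This account rests on a few compounds, and the source may have more. Where it says the series, first, only, none or still open, it means among the compounds named here.

Going by the values given here, compound 1 `CN1CCCN(CC(=O)NC2(c3ccc(Cl)c(Cl)c3)C(=O)Nc3cc(Cl)cc(Cl)c32)CC1` gives in an in vitro functional assay on CHO-CREluc cells for antagonist activity at growth hormone secretagogue receptor type 1 (Homo sapiens), read by a luciferase reporter, with a stated time of 4 h (a lower number here means a stronger inhibitor, a higher number a weaker inhibitor), a potency of 64 nM, the only outright number among the two measured compounds. Compound 2 `CN(C)CCN(C)CC(=O)NC1(c2ccc(Cl)cc2)C(=O)Nc2cc(Cl)c(Cl)cc21` differs from it in several places at once. For compound 2 this assay reports only > 10000 nM, which is a limit of the assay rather than a number (the limit of > 10000 nM in this assay, at which 1 of the 2 values shown sits). Compound 3 `CCN1CCCC(CC(=O)NC2(c3ccc(Cl)c(Cl)c3)C(=O)Nc3cc(Cl)cc(Cl)c32)C1` carries 1-ethylpiperidin-3-yl in place of 4-methyl-1,4-diazepan-1-yl on a saturated chain carbon bound to a carbonyl carbon. Among the compounds with values here, no single-point step has been measured here, so the step from compound 1 to compound 3 is expected to be a modest loss, a 2.3-fold higher number from compound 1 to compound 3 (0.37 log units; beyond the scatter), within the reach of ordinary scatter. Compound 3 is therefore estimated at 150 nM, between 40 nM and 600 nM.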

Compound 3, half-maximal inhibitory concentration: 47 nM
The estimate for compound 3 lay 3.2-fold (0.50 log units) above the measured number; the measured number falls inside the stated range.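

Setting 1-ethylpiperidin-3-yl in place of 4-methyl-1,4-diazepan-1-yl on a saturated chain carbon bound to a carbonyl carbon gives a 1.4-fold lower number from compound 1 to compound 3 (0.13 log units; within the scatter) in this assay, so the two compounds cannot be told apart there. At this place, then, a six-membered ring with one hetero atom serves as well as a seven-membered ring with two. Nothing shown here accounts for this step. The compounds shown leave open whether a ring nitrogen is needed at all, as a cyclohexyl group would test, and how a morpholine or a carboxylic acid would fare at this place.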